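Inverting the single stereocentre of compound 3

The source may hold more compounds than are shown below. What is called first, only, known or untested is meant among the compounds shown, and "the series" means these compounds.

Measured so far in a functional assay on NCI/ADR-RES cells (Homo sapiens) for inhibition, read by luminescence, with a stated time of 72 h (a higher number here means a weaker inhibitor, a lower number a stronger inhibitor), are three compounds.
- compound 1 `Nc1ncnc2c1nc(Sc1cc3c(cc1Br)OCCO3)n2CCC1CCN(C=O)CC1` gives 2100 nM
- compound 2 `Nc1ncnc2c1nc(Sc1cc3c(cc1Br)OCCO3)n2CCC1CCN(C(=O)CO)CC1` gives 10000 nM
- compound 3 `C[C@H](O)C(=O)N1CCC(CCn2c(Sc3cc4c(cc3Br)OCCO4)nc3c(N)ncnc32)CC1` gives 6500 nM

Compound 3 lies within the scatter of its nearest neighbour (a 1.5-fold lower number from compound 2 to compound 3 (0.19 log units; within the scatter)) and beyond the scatter of the furthest one (a 3.1-fold higher number from compound 1 to compound 3 (0.49 log units; beyond the scatter)). The remaining measured step is also modest (a 4.8-fold higher number from compound 1 to compound 2 (0.68 log units; beyond the scatter)) and involves the same carbonyl carbon.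

Compound 4 `C[C@@H](O)C(=O)N1CCC(CCn2c(Sc3cc4c(cc3Br)OCCO4)nc3c(N)ncnc32)CC1` changes only the configuration of compound 3 (the two compounds have the same atoms and bonds and differ only in configuration as drawn: 1 of 1 stereo elements differ; a stereocentre at a saturated chain carbon is drawn S in compound 3 and R in compound 4). Within the data shown here, no measured step inverts a configuration, so the data offer no direct guide. The closest evidence is the methyl step above, which stayed within the scatter, and the two modest steps show that this part of the molecule can still shift the number. No step beyond the scatter is therefore expected, and the direction is open, giving an estimated change (a 1.1-fold lower number from compound 3 to compound 4 (0.03 log units; within the scatter)) that is small. In this assay the expected value for compound 4 is 6000 nM on this reasoning, with an estimated range from 2500 nM to 13000 nM around it.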

Compound 4, half-maximal inhibitory concentration: 9800 nM
For compound 4 the middle estimate is 1.6-fold (0.21 log units) below the measured one; measured number inside the range.
By their numbers in this assay, from the lowest: compound 1; then compounds 3, 4 and 2 (each within the scatter of the next).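

In this assay, among these compounds, this is the first direct reading of configuration at this saturated chain carbon, and a 1.5-fold higher number from compound 3 to compound 4 (0.18 log units; within the scatter) leaves the two drawn forms unresolved. The R form also cannot be told apart from the compound lacking the methyl group, a 1.0-fold lower number from compound 2 to compound 4 (0.01 log units; within the scatter), while replacing the hydrogen on the carbonyl carbon of compound 1 with 1-hydroxyethyl gives a step beyond the scatter in this configuration too, a 4.7-fold higher number from compound 1 to compound 4 (0.67 log units; beyond the scatter). The comparison of the two forms isolates configuration as the only variable: the fact that compounds 3 and 4 differ only in the configuration as drawn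

The compounds shown leave open whether an amine or a carboxylic acid in place of the hydroxyl group, or a longer chain in place of the methyl group, would give a step beyond the scatter. They also leave open whether configuration at this carbon would separate two forms carrying such groups.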